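Adding a large group to compound 3

This account rests on a few compounds, and the source may have more. Where it says the series, first, only, none or still open, it means among the compounds named here.

In an ADME assay on MRC5 cells (Homo sapiens) for cytotoxicity, read by fluorescence and resazurin assay, with a stated time of 3 days (a higher number here means that more compound is needed for the effect, a lower number that less compound is needed), compound 1 `COC1(c2nc3ccccc3s2)C=CC(=O)C=C1` gives 1100 nM, compound 2 `O=C1C=CC(O)(c2cc3ccc(F)cc3n2S(=O)(=O)c2ccccc2)C=C1` gives 170 nM and compound 3 `O=C1C=CC(O)(c2cc3ccccc3n2S(=O)(=O)c2ccccc2)C=C1` gives 110 nM. Compound 3 therefore sits close to compound 2, while compound 1 shows a clearly higher number, and so needs more compound for the same effect.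

Compound 4 `CN1CCN(C(=O)CCc2ccc(S(=O)(=O)n3c(C4(O)C=CC(=O)C=C4)cc4ccccc43)cc2)CC1` has 2-((4-methylpiperazin-1-yl)carbonyl)ethyl in place of hydrogen on an aromatic carbon, para to a large group: 2-((4-methylpiperazin-1-yl)carbonyl)ethyl in place of hydrogen on an aromatic carbon.

Among the measured compounds shown here, only one measured step offers any guide. It is a 1.5-fold lower number from compound 2 to compound 3 (0.19 log units; within the scatter), which swaps fluoro for hydrogen, a far smaller change made at a different place. For the measured compounds named here, no measured compound carries the new group, so the data give no firm direction, and no shift beyond the scatter is expected. The estimate amounts to a 1.4-fold higher number from compound 3 to compound 4 (0.13 log units; within the scatter). On these data alone, the expected value for compound 4 is 150 nM, with an estimated range from 40 nM to 600 nM, kept wide because the added group is untested.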

Compound 4, half-maximal effective concentration: 52 nM
Compound 4: the middle estimate sits 2.9-fold (0.46 log units) above what was measured, within the range that was stated.
By their numbers in this assay, from the lowest: compound 4; then compounds 3 and 2 (each within the scatter of the next); then compound 1.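

In this assay, putting 2-((4-methylpiperazin-1-yl)carbonyl)ethyl on an aromatic carbon, para to a large group, gives a 2.1-fold lower number from compound 3 to compound 4 (0.33 log units; beyond the scatter) as the step. Among the compounds shown here, compounds 2 and 3 carry only hydrogen at this place, so compound 4 is the first to show that it accepts a group of 11 heavy atoms with a six-membered non-aromatic ring, and that less compound is then needed for the effect, not more. Nothing measured alongside this result accounts for the step.

Which part of the added group goes with the lower number stays open: the ring, the carbonyl or the chain. Also open, on these data alone, is whether a carboxylic acid, or a shorter chain ending in a plain amine, would move the number the same way at this place.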